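Hexyl in place of bromo on the pyridine ether core

The compounds below may be only part of what the source reports. "The series", "measured", "known", "first", "only" and "open" are said of these compounds alone.

Measured so far:
compound 1 `CN1CCC[C@H]1COc1cccnc1Br` — 451 nM
compound 2 `CN1CCC[C@H]1COc1cccnc1I` — 606 nM
compound 3 `CN1CCC[C@H]1COc1cncc(Br)c1` — 0.27 nM

In an assay on membranes from brain for displacement of a labelled ligand from Neuronal acetylcholine receptor; alpha4/beta2 (Rattus norvegicus) (a higher number here means a weaker inhibitor, a lower number a stronger inhibitor), compound 3 stands lowest of the three numbers; compound 1 gives 451 nM and compound 2 gives 606 nM, both far higher. Compound 4 `CCCCCCc1cncc(OC[C@@H]2CCCN2C)c1` is not yet measured. It differs from compound 3 by hexyl in place of bromo on an aromatic carbon. Among the measured compounds shown here, the only measured step, a 1.3-fold higher number from compound 1 to compound 2 (0.13 log units; within the scatter), swaps one halogen for another on a different core and is within the scatter, so no measured step bears on replacing a halogen with a six-carbon chain. Compound 4 is therefore expected to show a weaker number, estimated at 10 nM with a range from 1 nM to 100 nM, a step of a 37-fold higher number from compound 3 to compound 4 (1.57 log units; beyond the scatter).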

Compound 4, inhibition constant: 0.32 nM
Compound 4: the middle estimate sits 31-fold (1.49 log units) above what was measured, outside the stated range (below it).
By their numbers in this assay, from the lowest: compounds 3 and 4 (each within the scatter of the next); then compounds 1 and 2 (each within the scatter of the next).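

In this assay the change on this aromatic carbon, two atoms from the ring nitrogen, gives a 1.2-fold higher number from compound 3 to compound 4 (0.07 log units; within the scatter), so hexyl takes the place of bromo here without a readable change in the number. This position therefore accepts a six-carbon chain as well as a halogen, which the swap of one halogen for another on the core of compound 1 could not show. Nothing at hand accounts for this result.

As far as these compounds go, whether a longer chain, a propyl group or an amine at this place would keep the number remains open. So does whether hexyl would give the same outcome on the core of compound 1.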